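A few compounds are considered here, and "the series" means these few. Any claim that something is new, unique, unknown or untested is made for them only; others in the source may bear on it.

Measured in a functional assay on HL-60 cells (Homo sapiens) for antiproliferative activity, read by MTT assay, with a stated time of 48 h; a higher number here means a weaker inhibitor, a lower number a stronger inhibitor:
- compound 1 `NC(=O)C[C@H](NC(=O)c1cc2ccccc2cn1)C(=O)OCc1ccccc1`: 86.9 nM
- compound 2 `O=C(CNC(=O)c1cc2ccccc2cn1)OCc1ccccc1`: 57.4 nM
- compound 3 `O=C(C[C@H](NC(=O)c1cc2ccccc2cn1)C(=O)OCc1ccccc1)OCc1ccccc1`: 74 nM

Compound 3 stands within the scatter of both other compounds, with steps of a 1.2-fold lower number from compound 1 to compound 3 (0.07 log units; within the scatter) and a 1.3-fold higher number from compound 2 to compound 3 (0.11 log units; within the scatter). Compound 4 `CC[C@@H](C)[C@H](NC(=O)c1cc2ccccc2cn1)C(=O)OCc1ccccc1` differs from compound 3 by one change, sec-butyl in place of (benzyloxycarbonyl)methyl on a saturated chain carbon bound to an amide-type nitrogen and a carbonyl carbon. Sec-butyl occurs in no measured compound, so no measured step speaks for it directly. Two steps do change the same place, a saturated chain carbon bound to an amide-type nitrogen and a carbonyl carbon. Hydrogen replacing carbamoylmethyl gives a 1.5-fold lower number from compound 1 to compound 2 (0.18 log units; within the scatter), and (benzyloxycarbonyl)methyl replacing hydrogen gives a 1.3-fold higher number from compound 2 to compound 3 (0.11 log units; within the scatter). Both lie within the scatter, so in this assay no step beyond the scatter is expected, in either direction, although the data cannot exclude a surprise from the new group. The expected step is a 1.1-fold lower number from compound 3 to compound 4 (0.02 log units; within the scatter). For compound 4 the estimated value is 70 nM, with an expected range of 33 nM to 150 nM.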

Compound 4, half-maximal inhibitory concentration: 96.4 nM
Compound 4: the middle estimate sits 1.4-fold (0.14 log units) below what was measured, within the range that was stated.
By their numbers in this assay, from the lowest: compounds 2, 3, 1 and 4 (each within the scatter of the next).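

At the saturated chain carbon bound to an amide-type nitrogen and a carbonyl carbon, this assay gives a 1.3-fold higher number from compound 3 to compound 4 (0.11 log units; within the scatter) when sec-butyl, with no ring and 0 hydrogen-bond acceptors, replaces (benzyloxycarbonyl)methyl. Sec-butyl also stays within the scatter of the other two groups, with a 1.7-fold higher number from compound 2 to compound 4 (0.23 log units; within the scatter) against hydrogen and a 1.1-fold higher number from compound 1 to compound 4 (0.05 log units; within the scatter) against carbamoylmethyl, so the flat picture that the earlier compounds gave for carbonyl-bearing groups and hydrogen now extends to a group of carbon alone. No evidence is available to explain why all these steps remain so small.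

From the compounds shown here alone, whether an amine, a carboxylic acid or a longer chain at this carbon would give a step beyond the scatter remains open. So does the effect of the opposite stereochemistry at this carbon or within the sec-butyl group.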